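The compounds below may be only part of what the source reports. "The series", "measured", "known", "first", "only" and "open" are said of these compounds alone.

Measured compounds: compound 1 `COc1cc(Cl)ccc1C(=O)Nc1cc(Cl)ccc1O`, which in a functional assay on HepG2 cells (Homo sapiens) for cytotoxicity, with a stated time of 24 h (a lower number here means a stronger inhibitor, a higher number a weaker inhibitor), gives 87000 nM; compound 2 `COc1cc(Cl)ccc1C(=O)Nc1cc(Br)ccc1O`, which gives 5630 nM; compound 3 `COc1cc(Cl)ccc1C(=S)Nc1cc(Cl)ccc1O`, which gives 8490 nM.

Compound 1 and compound 2 share one core and differ only by bromo in place of chloro on an aromatic carbon, a change that brought a 15-fold lower number from compound 1 to compound 2 (1.19 log units; beyond the scatter). Compound 3 has a different core from compound 1, and the difference between the two cores is not broken down here. Its value sits near that of compound 2 and well away from that of compound 1. Compound 4 `COc1cc(Cl)ccc1C(=S)Nc1cc(Br)ccc1O` has not yet been measured. It differs from compound 3 by bromo in place of chloro on an aromatic carbon, the same change as between compound 1 and compound 2, the two place descriptions agreeing word for word. Resting on the single earlier step of a 15-fold lower number from compound 1 to compound 2 (1.19 log units; beyond the scatter), compound 4 is expected in this assay to give 800 nM, between 250 nM and 3000 nM. Among the compounds with values here, the step from compound 3 to compound 4 is estimated as an 11-fold lower number from compound 3 to compound 4 (1.03 log units; beyond the scatter), kept a little smaller than the earlier one as only one example supports it.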

Compound 4, half-maximal inhibitory concentration: 6530 nM
Beside the measured number, compound 4's estimate is 8.2-fold (0.91 log units) below it; the whole stated range lies below it.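

In this assay, bromo in place of chloro on an aromatic carbon gave a 1.3-fold lower number from compound 3 to compound 4 (0.11 log units; within the scatter) and so made no difference beyond the scatter on this core. Set beside the earlier step, the same change did not carry over from one core to the other: the same change on two cores in this assay, a 15-fold lower number (1.19 log units; beyond the scatter) from compound 1 to compound 2 and a 1.3-fold lower number (0.11 log units; within the scatter) from compound 3 to compound 4, 12-fold (1.08 log units) apart, beyond the scatter of two such steps

This shows that, across these two pairs, the size of the step depends on the core that carries it, so the result on the core of compound 1 could not be transferred to the core of compound 3. It does not show what sets the two cores apart, and two pairs give no rule for any further core.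

The compounds shown leave open how either core would respond to other groups at this place, such as iodo, methyl, an amine or a nitrile. They also leave open whether a longer chain in place of the methoxy group would alter the step.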